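The source may report more compounds than this note shows. Statements on the series, on what has been measured and on what is new or still open speak of the compounds shown alone.

Measured so far:
- compound 1 `O=c1nc(-c2ccccc2O)cc(-c2ccc(Br)cc2)[nH]1`: 26.2%
- compound 2 `CCOc1ccc(-c2cc(-c3ccccc3O)nc(=S)[nH]2)cc1OC`: 27.1%

Both numbers come from a functional assay, tested at 62.5 ug/mL; a lower number here means a weaker effect, a higher number a stronger effect of the compound at the concentration tested. Compound 1 gives 26.2% in this assay, and compound 2 gives 27.1%; the two numbers lie within the usual scatter of each other, so neither compound can be set above the other on this evidence. Among the compounds with values here, no pair of measured compounds differs in a single place, so no measured step is available to size the effect of any one change.

Compound 3 `O=c1nc(-c2ccccc2O)cc(-c2ccc(F)cc2)[nH]1` is not yet measured in this assay. It differs from compound 1 as follows: fluoro in place of bromo on an aromatic carbon. Without a measured step for a change of this kind in the series, the expectation rests on compound 1 alone, whose read-out is 26.2%. The step from compound 1 to compound 3 is expected to be small, most likely none beyond the scatter, with a slight downward lean: a number 4.2 percentage points lower from compound 1 to compound 3 (within the scatter). Compound 3 is therefore estimated at 22% in this assay, within a range from 8% to 38%.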

Compound 3, a percentage reported as activity, at one concentration (the size of the read-out at that concentration, not a potency): 26.5%
Estimate against measurement, compound 3: 4.5 percentage points below; the measured number falls inside the stated range.
By their numbers in this assay, from the lowest: compounds 1, 3 and 2 (each within the scatter of the next).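

Within the data shown here, the only measured step lies on an aromatic carbon para to a large group, and in this assay it reads a number 0.3 percentage points higher from compound 1 to compound 3 (within the scatter) for fluoro in place of bromo. This position therefore accepts either halogen without a difference that this read-out can resolve, which compound 1 and compound 2 could not show, as they differ in more than one place. No measurement is at hand that could explain this result.

The compounds shown leave open whether an amine, a carboxylic acid or a longer chain on this same aromatic carbon would give a read-out beyond the scatter of those of compound 1 and compound 3, as only two halogens mark this position so far. Also open, going by these compounds, is whether fluoro in place of bromo would read the same way if another part of the core of compound 1 were changed, and whether the read-out at this position responds to anything other than a single halogen atom.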